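Extending methoxy to ethoxy on the aromatic nitrogen substituent

The compounds below may be only part of what the source reports. "The series", "measured", "known", "first", "only" and "open" are said of these compounds alone.

Compound 1 `N#CC1=C(N)Oc2c(c3nc4ccccc4nc3c3ccccc23)C12C(=O)N(Cc1cnnn1-c1cccc(Cl)c1)c1ccccc12` gives 35200 nM in an ADME assay on L02 cells (Homo sapiens) for antiproliferative activity, read by MTT assay, with a stated time of 48 h; a higher number here means a weaker inhibitor, a lower number a stronger inhibitor.
Compound 2 `COc1ccc(-n2nncc2CN2C(=O)C3(C(C#N)=C(N)Oc4c3c3nc5ccccc5nc3c3ccccc43)c3ccccc32)cc1` gives > 50000 nM, which is a limit of this assay.
Compound 3 `COc1ccccc1-n1nncc1CN1C(=O)C2(C(C#N)=C(N)Oc3c2c2nc4ccccc4nc2c2ccccc32)c2ccccc21` gives > 50000 nM, also a limit of this assay.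

Compound 3 therefore stands at the limit, not at a number; the same holds for compound 2 because of the limit of > 50000 nM in this assay, at which 2 of the 3 values shown sit. The two steps from a number, an at least 1.4-fold higher number from compound 1 to compound 2 (0.15 log units; that floor lies within the scatter) and an at least 1.4-fold higher number from compound 1 to compound 3 (0.15 log units; that floor lies within the scatter), are floors within the scatter, and a step that the two limits leave unreadable from compound 2 to compound 3 cannot be read at all. Compound 4 `CCOc1ccccc1-n1nncc1CN1C(=O)C2(C(C#N)=C(N)Oc3c2c2nc4ccccc4nc2c2ccccc32)c2ccccc21` differs from compound 3 only by methyl in place of hydrogen on a saturated chain carbon bound to an oxygen on an aromatic ring. The two limits give no readable step to lean on, so no change beyond the scatter is expected in this assay. Compound 4 is expected to stay at 60000 nM, between 25000 nM and 150000 nM, a step that the limit leaves unreadable from compound 3 to compound 4.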

Compound 4, half-maximal inhibitory concentration: > 50000 nM
Compound 4: a limit, no number (the forecaster's own chance of this, stated with the estimate: 75%); the middle value is on the limit's open side.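

In this assay compound 4 gives > 50000 nM, which is a limit and not a number. The steps from compound 2 and compound 3 to compound 4 cannot be read, and the one floor that can be read is an at least 1.4-fold higher number from compound 1 to compound 4 (0.15 log units; that floor lies within the scatter). Extending methoxy to ethoxy thus adds one more compound to those at the same limit: the limit of > 50000 nM in this assay, at which 3 of the 4 values shown sit.

As far as these compounds go, how far compound 2, compound 3 and compound 4 lie past that limit stays open, and so does any effect of the extra methyl. Also open, from the compounds shown here alone, is whether an amine or a carboxylic acid in place of ethoxy would give a number in this assay.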